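Formyl-methoxyphenyl replaces methylphenyl on the shared core

The source may hold more compounds than are shown below. What is called first, only, known or untested is meant among the compounds shown, and "the series" means these compounds.

Of the compounds shown here, three built on a shared core have been measured in a functional assay on A549 cells (Homo sapiens) for cytotoxicity, read by MTT assay, with a stated time of 48 h; a lower number here means a stronger inhibitor, a higher number a weaker inhibitor. Compound 1 `COc1cc2c(cc1OC)CN(S(=O)(=O)c1ccc(-n3cc(COc4ccc(C=O)cc4)nn3)cc1)CC2` gives 31800 nM, compound 2 `O=c1cc(OCc2cn(-c3ccc(S(=O)(=O)N4CCc5ccccc5C4)cc3)nn2)c2ccccc2o1` gives 25300 nM, and compound 3 `COc1cc2c(cc1OC)CN(S(=O)(=O)c1ccc(-n3cc(COc4ccccc4C)nn3)cc1)CC2` gives 27200 nM. Among these three numbers compound 3 stands second highest, and its nearest neighbour is compound 2, while the three values all lie within the usual scatter of one another, so no order among them can be claimed.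

Among the measured compounds shown here, the one single-point step measured so far, a 1.2-fold lower number from compound 1 to compound 3 (0.07 log units; within the scatter), exchanged a formyl-bearing phenyl for a methyl-bearing phenyl on an oxygen on a saturated carbon and left the number essentially unchanged.

Compound 4 `COc1cc2c(cc1OC)CN(S(=O)(=O)c1ccc(-n3cc(COc4cc(C=O)ccc4OC)nn3)cc1)CC2` differs from compound 3 by 5-formyl-2-methoxyphenyl in place of 2-methylphenyl on an oxygen on a saturated carbon. This change is the reverse direction of the measured step in kind, in that a formyl-bearing phenyl again comes in, now joined by a methoxy group. Because a 1.2-fold lower number from compound 1 to compound 3 (0.07 log units; within the scatter) stayed within the scatter, the step from compound 3 to compound 4 is expected to stay within the scatter as well, giving a 1.1-fold higher number from compound 3 to compound 4 (0.04 log units; within the scatter). Compound 4 is therefore estimated at 30000 nM in this assay, with a range from 15000 nM to 60000 nM.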

Compound 4, half-maximal inhibitory concentration: 31900 nM
Estimate against measurement, compound 4: 1.1-fold (0.03 log units) below; low and high end bracket the measured number.
By their numbers in this assay, from the lowest: compounds 2, 3, 1 and 4 (each within the scatter of the next).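

In this assay, the exchange of 2-methylphenyl for 5-formyl-2-methoxyphenyl on an oxygen on a saturated carbon gives a 1.2-fold higher number from compound 3 to compound 4 (0.07 log units; within the scatter), so a group of 10 heavy atoms with 2 hydrogen-bond acceptors, in place of one of 7 heavy atoms with 0, leaves the number within the scatter. The exchange of 4-formylphenyl for 5-formyl-2-methoxyphenyl at the same place gives a 1.0-fold higher number from compound 1 to compound 4 (0.00 log units; within the scatter), which shows that the formyl-bearing group with a methoxy group also stays within the scatter of the one without it. Compounds 1, 3 and 4 now make three differently substituted phenyl groups at this place with no step beyond the scatter, and nothing available explains this flat result.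

All the groups shown at this place are substituted phenyl rings, so it remains open whether an amine, a carboxylic acid or a longer saturated chain there would move the number beyond the scatter. The compounds shown also include no pair that differs only in the methoxy groups of the shared core, so what those groups contribute cannot be told.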